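The source may report more compounds than this note shows. Statements on the series, on what has been measured and on what is new or still open speak of the compounds shown alone.

Measured compounds:
- compound 1, `Cc1cc(COc2ccccc2)nc(-c2ccccn2)n1`, 794 nM
- compound 2, `CCOc1cc(COc2cccc(F)c2)nc(-c2ccccn2)n1`, 251 nM

Both were tested in a functional assay on cells for antagonist activity at Free fatty acid receptor 1 (Homo sapiens), read by TR-FRET and inositol phosphate accumulation, with a stated time of 2 h; a higher number here means a weaker inhibitor, a lower number a stronger inhibitor. Compound 2 holds the lowest of the two numbers; its nearest neighbour, compound 1, gives 794 nM, a gap that lies beyond the usual scatter of such measurements. Among the compounds with values here, no single-point step between the two measured compounds is recorded, so only their two values can be compared.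

Compound 3, `CC(C)Nc1cc(COc2cccc(F)c2)nc(-c2ccccn2)n1`, has not yet been measured in this assay. It differs from compound 2 in one place: isopropylamino in place of ethoxy on an aromatic carbon. Within the data shown here, no measured pair shows what this exchange does on this core, so the size and direction of the step are unknown from the data; a step beyond the scatter is not expected either way.

On that basis compound 3 is estimated at 250 nM, with a range from 80 nM to 800 nM; the expected step from compound 2 to compound 3 is a 1.0-fold lower number from compound 2 to compound 3 (0.00 log units; within the scatter).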

Compound 3, half-maximal inhibitory concentration: 100 nM
Compound 3: middle estimate off by 2.5-fold (0.40 log units), on the high side; the measured number falls inside the stated range.
By their numbers in this assay, from the lowest: compound 3; then compound 2; then compound 1.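

Within the data shown here, the step in this assay is the first measured change at this position, the aromatic carbon next to the ring nitrogen, and isopropylamino in place of ethoxy gives a 2.5-fold lower number from compound 2 to compound 3 (0.40 log units; beyond the scatter). The step is modest but beyond the scatter, so the number at this position does respond to the group placed there, and an oxygen link to the core is not required for activity in this series. No measurement available here accounts for the step.

The compounds shown leave open whether the lower number goes with the amine nitrogen and its hydrogen or with the branched chain, a question that an isopropoxy or ethylamino group would address. They also leave open how a tertiary amine such as dimethylamino or a morpholine ring would read at this position.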